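A few compounds are considered here, and "the series" means these few. Any claim that something is new, unique, unknown or untested is made for them only; others in the source may bear on it.

In a functional assay on SH-SY5Y cells (Homo sapiens) for antagonist activity, read by cAMP accumulation (on this read-out lower numbers stand for lower potency and higher numbers for higher potency (the scale is a negative logarithm)), compound 1 (`CCCOc1ccc(Cc2ccc(NC3=NCCN3)cc2)cc1`) gives 8.8 and compound 2 (`CC(C)Oc1ccc(Cc2ccc(NC3=NCCN3)cc2)cc1`) gives 8.8, while compound 3 (`CCCCOc1ccc(Cc2ccc(NC3=NCCN3)cc2)cc1`) gives 9 on the same scale. Compound 3 thus stands within the scatter of both other compounds, and the three numbers cannot be ranked. Compound 4 (`FC(F)(F)COc1ccc(Cc2ccc(NC3=NCCN3)cc2)cc1`), not yet measured, departs from compound 3 in one place (trifluoromethyl in place of propyl on a saturated chain carbon bound to an oxygen on an aromatic ring): trifluoromethyl in place of propyl on a saturated chain carbon bound to an oxygen on an aromatic ring, which amounts to butoxy to 2,2,2-trifluoroethoxy. All three measured steps vary this same chain (no change at the digits printed from compound 1 to compound 2 (within the scatter); a number 0.20 log units higher from compound 1 to compound 3 (within the scatter); a number 0.20 log units higher from compound 2 to compound 3 (within the scatter)). Each of them stays within the scatter, so the number has so far tolerated propyl, isopropyl and butyl alike. None of these compounds carries fluorine, however, and the data hold no direct example of the entering group. The flat steps argue against a large shift, while the untested group leaves room for a modest loss. The expected change in this assay is therefore small and downward (a number 0.50 log units lower from compound 3 to compound 4 (beyond the scatter)). The estimate for compound 4 is 8.5 (expected range 8 to 9).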

Compound 4, negative logarithm of the antagonist equilibrium constant: 8.7
Beside the measured number, compound 4's estimate is 0.20 log units below it, and the stated range covers the measured number.
By their numbers in this assay, from the lowest: compounds 4, 1, 2 and 3 (each within the scatter of the next).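

The result shows that this position, on an oxygen on an aromatic ring, accepts a fluorinated chain as well as the plain alkyl chains in this assay: trifluoromethyl in place of propyl on the saturated chain carbon stays within the scatter (a number 0.30 log units lower from compound 3 to compound 4 (within the scatter)). The comparisons with the two shorter chains, one branched and one straight, also stay within the scatter (a number 0.10 log units lower from compound 2 to compound 4 (within the scatter)) (a number 0.10 log units lower from compound 1 to compound 4 (within the scatter)), so the tolerance seen among propyl, isopropyl and butyl now extends to a group with carbon-fluorine bonds, and the four numbers still cannot be ranked. Nothing available explains why this change is tolerated.

From the compounds shown here alone, whether the same tolerance in this assay holds for an amine, a carboxylic acid, a phenyl ring or a longer chain such as octyl on this oxygen stays open. All four compounds also share the same core, so the compounds shown say nothing about how a fluorinated chain would behave if the core itself were changed.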